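Branching the Amide Chain: Butyl to Isobutyl

The source may report more compounds than this note shows. Statements on the series, on what has been measured and on what is new or still open speak of the compounds shown alone.

Measured so far:
compound 1 `NC(=O)CC[C@H](NS(=O)(=O)c1ccc([N+](=O)[O-])cc1)C(=O)O` — in an assay for inhibition of matrix metalloproteinase-9 (Homo sapiens), with stated times of 1 h, 1 min and 30 min (on this read-out lower numbers stand for stronger inhibition and higher numbers for weaker inhibition), compound 1 gives 7000 nM
compound 2 `CCCCNC(=O)CC[C@H](NS(=O)(=O)c1ccc([N+](=O)[O-])cc1)C(=O)O` — in this assay compound 2 gives 6360 nM

Compound 2 carries a butyl group on the amide-type nitrogen where compound 1 carries only hydrogen. Its number is the lower of the two shown, yet the step of a 1.1-fold lower number from compound 1 to compound 2 (0.04 log units; within the scatter) lies within the scatter, so the two compounds cannot be told apart on these data.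

Compound 3 `CC(C)CNC(=O)CC[C@H](NS(=O)(=O)c1ccc([N+](=O)[O-])cc1)C(=O)O` is not yet measured. It differs from compound 2 by isopropyl in place of propyl on a saturated chain carbon bound to an amide-type nitrogen; the same difference, cut one bond further out, reads butyl to isobutyl, or butylcarbamoyl to isobutylcarbamoyl. For the measured compounds named here, the only measured step that touches this part of the molecule is a 1.1-fold lower number from compound 1 to compound 2 (0.04 log units; within the scatter), and it was small: adding the whole butyl chain barely moved the number. Rearranging three carbons within that chain is a smaller change still, so no step beyond the scatter is expected in this assay. The estimate for compound 3 is therefore 6000 nM, with a range of 3000 nM to 12000 nM, meaning an expected step of a 1.1-fold lower number from compound 2 to compound 3 (0.03 log units; within the scatter).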

Compound 3, half-maximal inhibitory concentration: 5140 nM
Compound 3: the middle estimate sits 1.2-fold (0.07 log units) above what was measured, within the range that was stated.
By their numbers in this assay, from the lowest: compounds 3, 2 and 1 (each within the scatter of the next).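

In this assay the branch, isopropyl in place of propyl on a saturated chain carbon bound to an amide-type nitrogen, gives a 1.2-fold lower number from compound 2 to compound 3 (0.09 log units; within the scatter) and leaves compound 2 and compound 3 impossible to tell apart on these data. The earlier compounds shown here compared only a straight butyl chain with the amide hydrogen, whereas the comparison of the branched chain with that hydrogen gives a 1.4-fold lower number from compound 1 to compound 3 (0.13 log units; within the scatter) and so shows that the isobutyl chain cannot be told apart from it either. Nothing available accounts for how close these three compounds lie.

From the compounds shown here alone, what remains open is whether any group on this nitrogen can produce a step beyond the scatter, for example a much longer chain, a phenyl ring, or a chain ending in an amine or a carboxylic acid. The compounds shown also leave open whether a change elsewhere in the shared core, such as a methoxy group in place of the nitro group, would shift the number by more than these chain changes do.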